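This account rests on a few compounds, and the source may have more. Where it says the series, first, only, none or still open, it means among the compounds named here.

Compound 1 `OB(O)c1ccc2ncnc(Nc3ccc(F)c(Cl)c3)c2c1` was examined in an assay on isolated protein for inhibition of vascular endothelial growth factor receptor 1 (Homo sapiens), read by ELISA, with a stated time of 20 min; a lower number here means a stronger inhibitor, a higher number a weaker inhibitor. In this assay compound 1 gives only a limit, > 1000 nM, and not a number. Compound 2 `COCCOc1cc2ncnc(Nc3cccc(B(O)O)c3)c2cc1OC` was examined in the same way. In this assay compound 2 likewise gives only the limit > 1000 nM, not a number. Both values shown sit at the limit of > 1000 nM in this assay, at which 2 of the 2 values shown sit, so compound 1 stands with the other measured compound at the edge of what this assay reports, and no order between the two can be stated. Compound 3 `OB(O)c1ccc2ncnc(Nc3cccc(Cl)c3)c2c1` differs from compound 1 by hydrogen in place of fluoro on an aromatic carbon. For the measured compounds named here, no step between two measured compounds is available, and the numbers therefore give no size of change to lean on. Compound 3 is expected to remain near the limit, with an estimated value of 3000 nM and a range from 800 nM to 15000 nM. The step that the limit leaves unreadable from compound 1 to compound 3 is expected to be none beyond the scatter.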

Compound 3, half-maximal inhibitory concentration: > 1000 nM
Compound 3 gave a limit, no number; the forecaster's own chance of this, stated with the estimate: 80%; the middle value does not contradict the limit.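

Compound 1 and compound 3 each give only a limit and not a number, so no step between them can be read in this assay: the limit of > 1000 nM in this assay, at which 3 of the 3 values shown sit.

The compounds shown leave open how strongly any of them inhibits in this assay, and whether hydrogen in place of fluoro on an aromatic carbon changes that at all.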